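Taking one methoxy from compound 1

This account rests on a few compounds, and the source may have more. Where it says the series, first, only, none or still open, it means among the compounds named here.

In a functional assay on LoVo cells (Homo sapiens) for cytotoxicity, read by MTT assay, with a stated time of 72 h (on this read-out higher numbers stand for weaker inhibition and lower numbers for stronger inhibition), compound 1 `COc1cc(/C=C/C=O)cc(OC)c1OC/C=C(\C)CCC=C(C)C` gives 23000 nM. Compound 2 `COc1cc(/C=C/C=O)cc(OC)c1OCC=C(C)C` gives 31000 nM, so the two numbers lie within the scatter of each other and compound 1 stands clearly apart from neither end of this small set. Compound 3 `COc1cc(/C=C/C=O)ccc1OC/C=C(\C)CCC=C(C)C` has not yet been measured. It differs from compound 1 by hydrogen in place of methoxy on an aromatic carbon. Going by the values given here, only one measured step is available, a 1.3-fold higher number from compound 1 to compound 2 (0.13 log units; within the scatter), and it is a change on the chain, hydrogen in place of 3-methylbut-2-en-1-yl, with both methoxy groups kept. It therefore bears only indirectly on compound 3, showing that one sizeable edit elsewhere in the molecule left the number within the scatter. Among the compounds with values here, no measured compound lacks a methoxy group, so the data give no direction for this change, and no shift beyond the scatter is expected, though with wide uncertainty. The expected change is a 1.1-fold higher number from compound 1 to compound 3 (0.05 log units; within the scatter). For compound 3 the estimated value is 26000 nM, with an expected range from 10000 nM to 60000 nM.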

Compound 3, half-maximal inhibitory concentration: 12000 nM
Beside the measured number, compound 3's estimate is 2.2-fold (0.34 log units) above it; the range from low to high includes it.
By their numbers in this assay, from the lowest: compounds 3, 1 and 2 (each within the scatter of the next, the first and the last beyond it).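

Removing one methoxy from the aromatic ring of compound 1 gives a 1.9-fold lower number from compound 1 to compound 3 (0.28 log units; within the scatter) in this assay, so at this position, ortho to a large group and meta to both the 2-formylethenyl group and the remaining methoxy group, hydrogen serves as well as methoxy within the resolution of this measurement. Until now, the only measured edit had been on the chain, and this step extends the same picture to the ring: compound 3 retains its cytotoxic read-out without this methoxy group, which is therefore not required for it in these cells. Nothing shown explains why the number falls where it does, and no supporting measurement bears on the result.

The compounds shown leave open whether a hydroxyl, a fluorine or a longer alkoxy group such as ethoxy at this same carbon would move the number beyond the scatter, in either direction. They also leave open whether hydrogen in place of methoxy behaves the same way on the shorter chain of compound 2, and what happens when the remaining methoxy group is replaced as well.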